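Shifting the nitro group around the aromatic ring

The source may hold more compounds than are shown below. What is called first, only, known or untested is meant among the compounds shown, and "the series" means these compounds.

- compound 1 `C[C@H]1CC[C@@H]2[C@@H](OC(=O)[C@]23CC(c2ccccc2)=NO3)[C@]2(C)C(=O)C=C[C@@]12O` gives 45400 nM
- compound 2 `C[C@H]1CC[C@@H]2[C@@H](OC(=O)[C@]23CC(c2ccc([N+](=O)[O-])cc2)=NO3)[C@]2(C)C(=O)C=C[C@@]12O` gives 9000 nM

In a functional assay on SW-620 cells (Homo sapiens) for cytotoxicity, read by sulforhodamine B assay, with a stated time of 48 h (on this read-out higher numbers stand for weaker inhibition and lower numbers for stronger inhibition), compound 2 holds the lower of the two numbers, which makes it the stronger inhibitor of this pair. Within the data shown here, the only measured step is a 5.0-fold lower number from compound 1 to compound 2 (0.70 log units; beyond the scatter), with nitro in place of hydrogen on an aromatic carbon.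

Compound 3 `C[C@H]1CC[C@@H]2[C@@H](OC(=O)[C@]23CC(c2cccc([N+](=O)[O-])c2)=NO3)[C@]2(C)C(=O)C=C[C@@]12O` keeps the nitro group but changes how it is attached. The change is 3-nitrophenyl in place of 4-nitrophenyl on a carbon with a double bond to nitrogen, with 3-nitrophenyl in place of 4-nitrophenyl on a carbon with a double bond to nitrogen, in a five-membered non-aromatic ring.

Among the measured compounds shown here, no measured compound carries the 3-nitrophenyl group, so the data do not show how the number depends on the site of the nitro group. For the measured compounds named here, the one guide is the modest step of a 5.0-fold lower number from compound 1 to compound 2 (0.70 log units; beyond the scatter), which suggests that compound 3 should stay closer to compound 2 than to compound 1, with no step beyond the scatter expected in this assay. The estimated change is a 1.3-fold higher number from compound 2 to compound 3 (0.12 log units; within the scatter). For compound 3 the expected value is 12000 nM, with an estimated range from 5000 nM to 30000 nM.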

Compound 3, half-maximal inhibitory concentration: 49000 nM
Compound 3: middle estimate off by 4.1-fold (0.61 log units), on the low side, outside the stated range (above it).
By their numbers in this assay, from the lowest: compound 2; then compounds 1 and 3 (each within the scatter of the next).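

In this assay the site of the nitro group on the aromatic ring turns out to decide the result: 3-nitrophenyl in place of 4-nitrophenyl, on the carbon with a double bond to nitrogen of the five-membered ring, gives a clear loss (a 5.4-fold higher number from compound 2 to compound 3 (0.74 log units; beyond the scatter)). Set against the plain phenyl group, the 3-nitrophenyl group brings no change beyond the scatter (a 1.1-fold higher number from compound 1 to compound 3 (0.03 log units; within the scatter)), so the gain seen earlier belongs to the 4-nitrophenyl group of compound 2 and not to the presence of a nitro group as such, a distinction the first pair alone could not draw. No supporting information is available to explain why the two attachments differ.

The compounds shown leave open whether the advantage of the 4-nitrophenyl group is specific to nitro or would also appear with another group in its place, such as an amine, a nitrile or a carboxylic acid. They also leave open whether the same difference between compound 2 and compound 3 would appear in cells other than those of this single test.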